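Iodo for nitrophenyl on two joined cores: cytotoxicity notes

A few compounds are considered here, and "the series" means these few. Any claim that something is new, unique, unknown or untested is made for them only; others in the source may bear on it.

Measured in an ADME assay on HEL cells (Homo sapiens) for cytotoxicity, with a stated time of 3 days; on this read-out higher numbers stand for lower toxicity in this test and lower numbers for higher toxicity in this test:
compound 1, `Cc1cc(-c2cccc([N+](=O)[O-])c2)c2ncc(CSCCc3ccccc3)n2c1`: 100 ug/mL.
compound 2, `Cc1cc(I)c2ncc(CSCCc3ccccc3)n2c1`: >= 4 ug/mL, a limit of the assay.
compound 3, `Cc1cc(-c2cccc([N+](=O)[O-])c2)cn2c(CSCCc3ccccc3)cnc12`: >= 100 ug/mL, a limit of the assay.

Compound 2 differs from compound 1 by iodo in place of 3-nitrophenyl on an aromatic carbon. The step is a step that the limit leaves unreadable from compound 1 to compound 2; the value of compound 2 is a limit, (the limit of >= 4 ug/mL in this assay, at which 1 of the 3 values shown sits). Compound 3 carries the same side chain on a core joined in another way; the difference between the two cores is not broken down here. The value of compound 3 is also a limit, (the limit of >= 100 ug/mL in this assay, at which 1 of the 3 values shown sits). Compound 4, `Cc1cc(I)cn2c(CSCCc3ccccc3)cnc12`, not yet measured in this assay, differs from compound 3 by iodo in place of 3-nitrophenyl on an aromatic carbon. This is the same kind of change as that from compound 1 to compound 2, but the place differs: here it is para to a fused ring, whereas in compound 1 the place was ortho to a fused ring. The step from compound 3 to compound 4 is expected at an at least 5.0-fold lower number from compound 3 to compound 4 (0.69 log units; beyond the scatter), resting on the earlier step that the limit leaves unreadable from compound 1 to compound 2, whose size the limit hides, so a limit may again be the outcome. Compound 4 is estimated at 20 ug/mL, between 4 ug/mL and 100 ug/mL.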

Compound 4, minimum cytotoxic concentration: >= 0.8 ug/mL
Compound 4 gave a limit, no number; the forecaster's own chance of this, stated with the estimate: 60%; the middle value does not contradict the limit.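

In this assay compound 4 gives >= 0.8 ug/mL, which is a limit of the assay and not a number. Compound 3 also stands at a limit, so no step can be read from compound 3 to compound 4. The compounds shown leave open how far iodo in place of 3-nitrophenyl moves this read-out on either core.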